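The compounds below may be only part of what the source reports. "The series", "measured", "known", "first", "only" and "open" are said of these compounds alone.

Working notes on the series, read in a functional assay on CNE-2 cells (Homo sapiens) for antiproliferative activity, read by sulforhodamine B assay, with a stated time of 48 h; a higher number here means a weaker inhibitor, a lower number a stronger inhibitor. Compound 1 `COc1ccc(C(=O)/C=C/c2ccccc2-c2ccc(F)nc2)cc1OC` gives 17000 nM. Among the measured compounds shown here, the only other measured member, compound 2 `COc1cc(C(=O)/C=C/c2ccccc2-c2ccc(F)nc2)ccc1O`, gives 19000 nM. These two values lie within the scatter of each other, so compound 1 holds no distinct place on the scale. Compound 3 `COc1ccc(C(=O)/C=C/c2ccccc2-c2ccc(F)nc2)cc1O` has not been measured. Its difference from compound 1 is hydrogen in place of methyl on an oxygen on an aromatic ring, methoxy to hydroxy: hydrogen in place of methyl on an oxygen on an aromatic ring. For the measured compounds named here, the one measured step of this kind, at the other methoxy group, is a 1.1-fold higher number from compound 1 to compound 2 (0.05 log units; within the scatter). That single step is thin evidence, but it gives no reason to expect a shift beyond the scatter in this assay. The expected size is a 1.1-fold higher number from compound 1 to compound 3 (0.05 log units; within the scatter). The estimated value for compound 3 is 19000 nM, with an expected range from 8000 nM to 45000 nM.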

Compound 3, half-maximal inhibitory concentration: 2100 nM
Compound 3: the middle estimate sits 9.0-fold (0.96 log units) above what was measured, and the stated range ends above it.
By their numbers in this assay, from the lowest: compound 3; then compounds 1 and 2 (each within the scatter of the next).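

In this assay the change from methoxy to hydroxy at this position gives an 8.1-fold lower number from compound 1 to compound 3 (0.91 log units; beyond the scatter) and so moves the number, while the same change at the other methoxy group gives a 1.1-fold higher number from compound 1 to compound 2 (0.05 log units; within the scatter) and does not. The outcome of hydrogen in place of methyl on an oxygen on an aromatic ring therefore depends on which of the two methoxy groups carries it, and the step at one group does not predict the step at the other in this series. Nothing measured here accounts for that difference between the two places.

The compounds shown leave open whether the lower number requires the hydroxy group itself, or whether an amine or an ethoxy group at the same place would give a similar value. They also leave open what happens when both methoxy groups are replaced by hydroxy groups on the shared core.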